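The source may hold more compounds than are shown below. What is called first, only, known or untested is meant among the compounds shown, and "the series" means these compounds.

Measured so far in an assay on isolated protein for inhibition of protoporphyrinogen oxidase (Homo sapiens), read by capillary electrophoresis; on this read-out lower numbers stand for stronger inhibition and higher numbers for weaker inhibition:
Compound 1, `C#CCSc1nc2cc(-n3nc(C(C)(C)C)sc3=O)c(F)cc2s1`, gives 9730 nM.
Compound 2, `CCOC(=O)CCCSc1nc2cc(-n3nc(C(C)(C)C)sc3=O)c(Br)cc2s1`, gives 245000 nM.

Of these two numbers, compound 2 stands at the higher one, and its gap to compound 1 lies well beyond the usual scatter of this assay, so compound 2 is the weaker inhibitor of the pair. The compound that follows is compound 3, `C#CCSc1nc2cc(-n3nc(C(C)(C)C)sc3=O)c(Br)cc2s1`, which has not yet been measured. It differs from compound 2 in one place: ethynyl in place of 2-(ethoxycarbonyl)ethyl on a saturated chain carbon bound to a sulfur. The 2-(ethoxycarbonyl)ethyl chain leaves, ethynyl enters, and the rest of the molecule stays as it is. Because compound 1 gives 9730 nM with the propargylsulfanyl group already in place, the change is expected to lower the number sharply. The step of a 16-fold lower number from compound 2 to compound 3 (1.21 log units; beyond the scatter) is estimated to lie beyond the scatter, in the direction of stronger inhibition. For compound 3 the expected inhibition constant in this assay is 15000 nM, with a likely range from 3000 nM to 70000 nM.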

Compound 3, inhibition constant: 20700 nM
Compound 3: middle estimate off by 1.4-fold (0.14 log units), on the low side; measured number inside the range.
By their numbers in this assay, from the lowest: compound 1; then compound 3; then compound 2.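

In this assay the change from (3-(ethoxycarbonyl)propyl)sulfanyl to propargylsulfanyl, with bromo kept in place, gives a 12-fold lower number from compound 2 to compound 3 (1.07 log units; beyond the scatter) and counts as a large step. The group on the sulfur therefore has a strong bearing on the number in this series, which the first two compounds could not show because they also differed in their halogen. Compound 3 also isolates that halogen for the first time: bromo in place of fluoro on an aromatic carbon gives a 2.1-fold higher number from compound 1 to compound 3 (0.33 log units; beyond the scatter) and counts as a modest step, while the data shown offer no explanation for either change.

With only two chains on the sulfur, the compounds shown do not tell whether the large step follows the ester or the chain length, a question that a plain propyl chain or the free carboxylic acid on the same sulfur could help to settle. Also open, as far as these compounds go, are whether the halogen step stays the same with other chains on the sulfur and how chloro or methyl on that aromatic carbon would read.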